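Swapping the aryl tail: from butyl to 4-chlorophenoxy

The source may report more compounds than this note shows. Statements on the series, on what has been measured and on what is new or still open speak of the compounds shown alone.

Measured so far in an assay on isolated protein for inhibition of Fatty-acid amide hydrolase 1 (Homo sapiens), read by fluorescence; a higher number here means a weaker inhibitor, a lower number a stronger inhibitor:
- compound 1 `O=C(Oc1ccc([N+](=O)[O-])cc1)N1CCN(S(=O)(=O)c2ccc(C3CCCCC3)cc2)CC1`: 333 nM
- compound 2 `O=C(Oc1ccc([N+](=O)[O-])cc1)N1CCN(S(=O)(=O)c2ccc(-c3ccccc3)cc2)CC1`: 437 nM
- compound 3 `CCCCc1ccc(S(=O)(=O)N2CCN(C(=O)Oc3ccc([N+](=O)[O-])cc3)CC2)cc1`: 179 nM

All three share the same core and differ only in the group on the aromatic carbon of the sulfonyl-bearing ring. Compound 3 has the lowest number of the three. Its nearest neighbour is compound 1, and the step of a 1.9-fold lower number from compound 1 to compound 3 (0.27 log units; within the scatter) stays within the scatter. Against compound 2 the gap is clearer: a 2.4-fold lower number from compound 2 to compound 3 (0.39 log units; beyond the scatter) is beyond the scatter, though modest. Between compound 1 and compound 2 the step of a 1.3-fold higher number from compound 1 to compound 2 (0.12 log units; within the scatter) is within the scatter.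

Compound 4 `O=C(Oc1ccc([N+](=O)[O-])cc1)N1CCN(S(=O)(=O)c2ccc(Oc3ccc(Cl)cc3)cc2)CC1` is not yet measured. It carries the change (4-chlorophenoxy in place of butyl on an aromatic carbon). The relevant measured steps are those that replace butyl with a ring-bearing group: going to cyclohexyl and to phenyl both gave higher numbers, one within the scatter and one modestly beyond it. A 4-chlorophenoxy group is again ring-based and larger than either, and only these three compounds inform the guess.

For compound 4 the expected step is a 2.1-fold higher number from compound 3 to compound 4 (0.33 log units; beyond the scatter), a modestly higher number in this assay. The estimate for compound 4 is 380 nM, with a range from 130 nM to 1100 nM.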

Compound 4, half-maximal inhibitory concentration: 153 nM
Beside the measured number, compound 4's estimate is 2.5-fold (0.40 log units) above it; the range from low to high includes it.
By their numbers in this assay, from the lowest: compounds 4, 3, 1 and 2 (each within the scatter of the next, the first and the last beyond it).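

In this assay, the step of a 1.2-fold lower number from compound 3 to compound 4 (0.07 log units; within the scatter) shows that this position accepts 4-chlorophenoxy, with its 8 heavy atoms and aromatic ring, as readily as butyl, with its 4 heavy atoms and no ring. Carrying a ring does not by itself settle the result, as the other two ring-bearing tails compare less well: the step is a 2.9-fold lower number from compound 2 to compound 4 (0.46 log units; beyond the scatter) against phenyl and a 2.2-fold lower number from compound 1 to compound 4 (0.34 log units; beyond the scatter) against cyclohexyl, both modest but beyond the scatter. The data offer no measurement that could explain these differences.

The compounds shown cannot tell whether the oxygen link or the chlorine accounts for the advantage of 4-chlorophenoxy over phenyl; a plain phenoxy group and a 4-chlorophenyl group at this place would separate the two. On these data alone, it also remains open how this position would respond to a chain longer than butyl, or to a tail ending in an amine or a carboxylic acid.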